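Chloro to methoxy: working notes on compound 4

A few compounds are considered here, and "the series" means these few. Any claim that something is new, unique, unknown or untested is made for them only; others in the source may bear on it.

Measured in a functional assay on MT4 cells (Homo sapiens) for inhibition; on this read-out lower numbers stand for stronger inhibition and higher numbers for weaker inhibition:
- compound 1 `C=C1[C@@H](O)[C@H](n2ccc(N)nc2=O)O[C@@H]1CO` gives 121000 nM
- compound 2 `C=C1[C@H](n2ccc(=O)[nH]c2=O)O[C@H](CO)[C@H]1O` gives > 500000 nM (a limit)
- compound 3 `C=C1[C@@H](O)[C@H](n2cnc3c(Cl)nc(N)nc32)O[C@@H]1CO` gives > 500000 nM (a limit)

Compound 3 stands at > 500000 nM in this assay, and this is a limit and not a number. Among the compounds with values here, it shares that position with compound 2, so the series so far is marked by the limit of > 500000 nM in this assay, at which 2 of the 3 values shown sit. Compound 1 alone gives a number, 121000 nM, and its core differs from that of compound 3 in more than one place. Within the data shown here, no measured pair differs in one place only, so no measured step is available as a guide.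

The next compound is compound 4 `C=C1[C@@H](O)[C@H](n2cnc3c(OC)nc(N)nc32)O[C@@H]1CO`, with methoxy in place of chloro on an aromatic carbon. The group stays on the same aromatic carbon and the rest of the structure is unchanged. The expected size of a number no higher from compound 3 to compound 4 (the limit leaves the size open) in this assay is none beyond the scatter, and the reading is expected to remain at or near the limit. For compound 4 the estimated value is 500000 nM, with an expected range from 150000 nM to 1000000 nM.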

Compound 4, half-maximal inhibitory concentration: > 500000 nM
Compound 4 was reported as a limit (the forecaster's own chance of this, stated with the estimate: 70%); the middle value sits exactly at the limit.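

Compound 3 and compound 4 are both reported as limits in this assay, so no step can be read between them, and the series remains defined by a single reading: the limit of > 500000 nM in this assay, at which 3 of the 4 values shown sit.

The compounds shown leave open whether methoxy in place of chloro on an aromatic carbon makes any difference to inhibition in this assay.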